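Swapping the terminal ring on a sulfonyl-linked benzamide

The compounds below may be only part of what the source reports. "The series", "measured", "known", "first", "only" and "open" are said of these compounds alone.

Two close relatives share a long chain that ends in a sulfonyl group carrying a saturated six-membered ring. Compound 1 `CC1(C)CCN(S(=O)(=O)CCCN2CCC(CNC(=O)c3cccc4c3OCCO4)CC2)CC1` bears a 4,4-dimethylpiperidin-1-yl ring there, and in an assay on isolated protein for inhibition of 5-hydroxytryptamine receptor 4 (Homo sapiens) (on this read-out lower numbers stand for stronger inhibition and higher numbers for weaker inhibition), compound 1 gives 0.126 nM. Compound 2 `O=C(NCC1CCN(CCCS(=O)(=O)N2CCN(Cc3cccnc3)CC2)CC1)c1cccc2c1OCCO2` carries a different ring in the same region, and in this assay compound 2 gives 0.159 nM. Compound 1 has the lower of these two numbers, but the gap to compound 2 lies within the scatter, so the two cannot be told apart.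

Compound 3 `CC(C)S(=O)(=O)N1CCN(S(=O)(=O)CCCN2CCC(CNC(=O)c3cccc4c3OCCO4)CC2)CC1` is the next variation: 4-(isopropylsulfonyl)piperazin-1-yl in place of 4,4-dimethylpiperidin-1-yl on a sulfonyl sulfur. Since the two measured compounds differ only in this region and sit within the scatter of each other, the step from compound 1 to compound 3 is expected to be small, a 1.6-fold higher number from compound 1 to compound 3 (0.20 log units; within the scatter), if anything a slightly higher number. Compound 3 is therefore estimated at 0.2 nM in this assay, within a range of 0.06 nM to 0.7 nM.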

Compound 3, inhibition constant: 0.126 nM
Compound 3: middle estimate off by 1.6-fold (0.20 log units), on the high side; low and high end bracket the measured number.
By their numbers in this assay, from the lowest: compounds 1, 3 and 2 (each within the scatter of the next).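

Replacing the ring on the sulfonyl sulfur with the larger 4-(isopropylsulfonyl)piperazin-1-yl, which brings a second ring hetero atom and two hydrogen-bond acceptors, gives no change at the digits printed from compound 1 to compound 3 (within the scatter) in this assay. On an amine nitrogen in a ring, isopropylsulfonyl in place of (pyridin-3-yl)methyl gives a 1.3-fold lower number from compound 2 to compound 3 (0.10 log units; within the scatter), so these two quite different groups cannot be told apart on this read-out. Nothing measured here accounts for this lack of separation.

From the compounds shown here alone, all three compounds carry a saturated six-membered ring on the sulfonyl sulfur, so it remains open whether an open-chain group such as a simple dialkylamine would give a similar number. It is also unknown whether a charged group on the ring, such as a carboxylic acid, would finally separate from these values in this assay.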